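The source may report more compounds than this note shows. Statements on the series, on what has been measured and on what is new or still open speak of the compounds shown alone.

Compound 1 `COc1cc2c(Oc3ccc(NC(=O)c4nnn(-c5ccc(C)cc5)c4C(F)(F)F)cc3F)ccnc2cc1OCCCN1CCCC1` gives 370 nM in a functional assay on A549 cells (Homo sapiens) for cytotoxicity, read by MTT assay, with a stated time of 72 h; on this read-out lower numbers stand for stronger inhibition and higher numbers for weaker inhibition.
Compound 2 `COc1cc2c(Oc3ccc(NC(=O)c4nnn(-c5ccc(C)cc5)c4C(F)(F)F)cc3F)ccnc2cc1OCCCN1CCC(C)CC1` gives 400 nM in this assay.
Compound 3 `COc1cc2c(Oc3ccc(NC(=O)c4nnn(-c5ccccc5C(F)(F)F)c4C(F)(F)F)cc3F)ccnc2cc1OCCCN1CCC(C)CC1` gives 220 nM in this assay.

All three share one core and differ only at the amine on the propyl chain or at the aryl group on the triazole nitrogen. Compound 2 has the highest number of the three, but the two steps around it are a 1.1-fold higher number from compound 1 to compound 2 (0.03 log units; within the scatter) and a 1.8-fold lower number from compound 2 to compound 3 (0.26 log units; within the scatter); neither is large enough to rank the three.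

Compound 4 `COc1cc2c(Oc3ccc(NC(=O)c4nnn(-c5ccc(C)cc5)c4C(F)(F)F)cc3F)ccnc2cc1OCCCN1CCN(C)CC1` has not been measured. It differs from compound 2 by 4-methylpiperazin-1-yl in place of 4-methylpiperidin-1-yl on a saturated chain carbon, three bonds along the chain from an oxygen on an aromatic ring, so the ring at the chain end keeps its size and gains a second nitrogen.

Among the compounds with values here, only one measured step touches the same place: the exchange of the amine from compound 1 to compound 2, which gave a 1.1-fold higher number from compound 1 to compound 2 (0.03 log units; within the scatter). That single step suggests the amine at the end of the chain is not where potency in this assay is decided, though one example is thin ground. The expected step is therefore a 1.1-fold lower number from compound 2 to compound 4 (0.02 log units; within the scatter), essentially none beyond the scatter.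

Compound 4 is accordingly estimated at 380 nM, with a plausible range from 170 nM to 850 nM.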

Compound 4, half-maximal inhibitory concentration: 370 nM
Estimate against measurement, compound 4: 1.0-fold (0.01 log units) above; measured number inside the range.
By their numbers in this assay, from the lowest: compounds 3, 1, 4 and 2 (each within the scatter of the next).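

Swapping 4-methylpiperidin-1-yl for 4-methylpiperazin-1-yl keeps the ring size but turns one ring carbon into a second nitrogen, and it gives a 1.1-fold lower number from compound 2 to compound 4 (0.03 log units; within the scatter) in this assay. Within the data shown here, changing ring size and ring atoms together reads the same way, with no change at the digits printed from compound 1 to compound 4 (within the scatter), so the three amines at the end of the propyl chain, all carrying 4-methylphenyl on the triazole nitrogen, cannot be told apart on this read-out, whereas the earlier compounds offered only a single exchange at this position. Nothing here measures why the second ring nitrogen leaves the number within the scatter, and no supporting data on the compounds are available to explain it.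

Still open, going by these compounds, is whether this tolerance extends to other chain ends, such as morpholin-4-yl, an open-chain dimethylamino group or a plain hydroxyl with no amine at all, or to a longer chain such as butyl. It is also unknown whether 4-methylpiperazin-1-yl would behave the same way with 2-(trifluoromethyl)phenyl on the triazole nitrogen, the aryl group of compound 3.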